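Swapping Methoxy for Fluoro on a Shared Diamine Core

The compounds below may be only part of what the source reports. "The series", "measured", "known", "first", "only" and "open" are said of these compounds alone.

Compound 2 `COc1ccc(Sc2nc3cc(N)cc(N)c3nc2-c2ccccc2)cc1` was tested in a functional assay on NCI/ADR-RES cells (Homo sapiens) for inhibition, read by sulforhodamine B assay, with a stated time of 48 h; on this read-out higher numbers stand for lower toxicity in this test and lower numbers for higher toxicity in this test. In this assay compound 2 gives only a limit of the test, < 100000 nM, not a number. Compound 1 `CCOC(=O)[C@H](CCC(=O)O)NC(=O)c1ccc(CNc2nc3cc(N)cc(N)c3nc2-c2ccccc2)cc1` likewise returns a limit, < 100000 nM. Both results sit at the same edge of the test: the limit of < 100000 nM in this assay, at which 2 of the 2 values shown sit. Compound 3 `Nc1cc(N)c2nc(-c3ccccc3)c(Sc3ccc(F)cc3)nc2c1` differs from compound 2 by fluoro in place of methoxy on an aromatic carbon. Going by the values given here, with no measured step to lean on, the expected step is small, within the scatter, and the estimated step is a step that the limit leaves unreadable from compound 2 to compound 3. Compound 3 is therefore expected to give about 30000 nM, in a range from 5000 nM to 100000 nM, most likely again reported only as a limit.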

Compound 3, concentration lethal to 50% of the cells: 72400 nM
Compound 3: middle estimate off by 2.4-fold (0.38 log units), on the low side, within the range that was stated.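

No step can be read between compound 2 and compound 3: compound 2 stands only as a limit in this assay. The compounds shown leave open whether, and how far, fluoro and methoxy differ on the shared core.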